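A few compounds are considered here, and "the series" means these few. Any claim that something is new, unique, unknown or untested is made for them only; others in the source may bear on it.

Measured so far:
compound 1 `Cc1cc(Nc2cc(-c3ccccc3)[nH]n2)n2nc(SCc3ccccc3Br)nc2n1` — 3650 nM
compound 2 `Cc1cc(Nc2cc(-c3ccccc3)[nH]n2)n2nc(SCc3ccc(C(F)(F)F)cc3)nc2n1` — 3520 nM
compound 3 `Cc1cc(Nc2cc(-c3ccccc3)[nH]n2)n2nc(SCc3cccc4ccccc34)nc2n1` — 3120 nM

In a functional assay on MGC-803 cells (Homo sapiens) for inhibition, read by MTT assay, with a stated time of 72 h (on this read-out higher numbers stand for weaker inhibition and lower numbers for stronger inhibition), compound 1 gives the highest of the three numbers, yet its steps of a 1.0-fold lower number from compound 1 to compound 2 (0.02 log units; within the scatter) and a 1.2-fold lower number from compound 1 to compound 3 (0.07 log units; within the scatter) lie within the scatter, as does a 1.1-fold lower number from compound 2 to compound 3 (0.05 log units; within the scatter). No ordering among the three is supported.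

Compound 4 `Cc1cc(Nc2cc(-c3ccccc3)[nH]n2)n2ncnc2n1` has not been measured. The change from compound 1 is hydrogen in place of (2-bromobenzyl)sulfanyl on an aromatic carbon. Each measured step swaps one aryl group for another on a saturated chain carbon bound to a sulfur and keeps the sulfanyl chain; none removes it, so none bears directly on this truncation, which is far larger than any step measured here.

In this assay compound 4 is expected to give a higher number, a step of a 2.5-fold higher number from compound 1 to compound 4 (0.39 log units; beyond the scatter), beyond the scatter but without a measured anchor. Compound 4 is estimated at 9000 nM, with a range from 2500 nM to 35000 nM.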

Compound 4, half-maximal inhibitory concentration: 21700 nM
Compound 4: the middle estimate sits 2.4-fold (0.38 log units) below what was measured; the range from low to high includes it.
By their numbers in this assay, from the lowest: compounds 3, 2 and 1 (each within the scatter of the next); then compound 4.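

In this assay, among the compounds shown here, hydrogen in place of (2-bromobenzyl)sulfanyl on the aromatic carbon gives a 5.9-fold higher number from compound 1 to compound 4 (0.77 log units; beyond the scatter), the first step beyond the scatter. The group at this position therefore matters for the read-out, although the aryl swaps on its chain did not separate compound 1, compound 2 and compound 3. Nothing shown gives a reason for this step.

Which part of the (2-bromobenzyl)sulfanyl group carries the step remains open. A methylsulfanyl group or an amine at this position would separate the contribution of the sulfur-linked chain from that of its aromatic ring.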